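Replacing the 6-methoxypyridazin-3-yl group of compound 1

The source may report more compounds than this note shows. Statements on the series, on what has been measured and on what is new or still open speak of the compounds shown alone.

- compound 1 (`COc1ccc(-n2nc(C(=O)N3CCOCC3)cc2-c2ccc(Cl)cc2)nn1`) 83 nM
- compound 2 (`COc1ccc(-n2nc(C(=O)OCCC(C)C)cc2-c2ccc(Cl)cc2)nn1`) 1330 nM

In a functional assay on a cell-free system (Platelet, plasma, Homo sapiens) for inhibition, read by turbidimetry, with a stated time of 3 min (on this read-out higher numbers stand for weaker inhibition and lower numbers for stronger inhibition), compound 1 stands lowest of the two at 83 nM and so inhibits more strongly than compound 2 at 1330 nM on this read-out. Compound 3 (`O=C(c1cc(-c2ccc(Cl)cc2)n(-c2ccc(=O)[nH]n2)n1)N1CCOCC1`) keeps the (morpholin-4-yl)carbonyl and 4-chlorophenyl groups and changes only the group on the aromatic nitrogen (a group of 7 heavy atoms (4 carbon, 2 nitrogen, 1 oxygen; one six-membered aromatic ring with 2 hetero atoms) in place of a group of 8 heavy atoms (5 carbon, 2 nitrogen, 1 oxygen; one six-membered aromatic ring with 2 hetero atoms), on an aromatic nitrogen). For the measured compounds named here, the single measured step (a 16-fold higher number from compound 1 to compound 2 (1.20 log units; beyond the scatter)) was large, but it sits on a carbonyl carbon, so no measured step touches this place directly. Going by the values given here, it shows only that one change can matter here. Somewhat weaker inhibition is expected, though this direction is a judgement rather than a measurement, with an estimated step (a 3.6-fold higher number from compound 1 to compound 3 (0.56 log units; beyond the scatter)) smaller than the measured one. For compound 3 the expected value is 300 nM within an estimated range from 60 nM to 1500 nM in this assay.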

Compound 3, half-maximal inhibitory concentration: 12600 nM
Estimate against measurement, compound 3: 42-fold (1.62 log units) below; measured number above the stated range.
By their numbers in this assay, from the lowest: compound 1; then compound 2; then compound 3.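

In this assay, the step on the aromatic nitrogen, a 150-fold higher number from compound 1 to compound 3 (2.18 log units; beyond the scatter), shows that the shared core is highly sensitive to change at this position. The step is also larger than the one on the carbonyl carbon, a 16-fold higher number from compound 1 to compound 2 (1.20 log units; beyond the scatter), so the group on the aromatic nitrogen counts for at least as much here as the ester-for-amide change did. The entering group carries 1 hydrogen-bond donor where 6-methoxypyridazin-3-yl carries 0, but nothing available explains why this swap weakens inhibition so sharply.

This single swap cannot separate the loss of the methoxy group from the appearance of the ring hydrogen-bond donor. Going by these compounds, whether an ethoxy group, an amine or a plain phenyl ring on this nitrogen would keep the inhibition of compound 1 remains open.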